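The source may hold more compounds than are shown below. What is called first, only, known or untested is meant among the compounds shown, and "the series" means these compounds.

In a functional assay on A549 cells (Homo sapiens) for antiproliferative activity, read by MTT assay, with a stated time of 72 h (on this read-out higher numbers stand for weaker inhibition and lower numbers for stronger inhibition), compound 1 `CC(C)(C)c1ccc(SC(=S)N2CCCCC2)cc1` gives 9130 nM and compound 2 `COc1ccc(SC(=S)N2CCN(C(=O)OC(C)(C)C)CC2)cc1` gives 712 nM, the lower of the two numbers by a margin beyond the usual scatter. Compound 3 `CC(C)(C)OC(=O)N1CCN(C(=S)Sc2cccc(Cl)c2)CC1` has not yet been measured. It carries 3-chlorophenyl in place of 4-methoxyphenyl on a sulfur. For the measured compounds named here, no measured pair shows what this swap does, so only a small rise within the scatter is expected, and the estimated change is a 1.3-fold higher number from compound 2 to compound 3 (0.10 log units; within the scatter). The expected value for compound 3 is 900 nM, with an estimated range of 250 nM to 3000 nM.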

Compound 3, half-maximal inhibitory concentration: 634 nM
The estimate for compound 3 lay 1.4-fold (0.15 log units) above the measured number, and the stated range covers the measured number.
By their numbers in this assay, from the lowest: compounds 3 and 2 (each within the scatter of the next); then compound 1.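

In this assay, 3-chlorophenyl in place of 4-methoxyphenyl on a sulfur gives a 1.1-fold lower number from compound 2 to compound 3 (0.05 log units; within the scatter) and so lies within the scatter: the two compounds cannot be told apart. For the compounds shown here, this is the first measured swap at this position, and it shows that two differently substituted phenyl groups can give matching numbers on this core. No available evidence explains this match. From the compounds shown here alone, whether an amine or a carboxylic acid on the sulfur-bound phenyl ring would read the same remains open. So does the effect of replacing the ring with a longer chain.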